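Returning to the four-position with a carbamoyl group

The compounds below may be only part of what the source reports. "The series", "measured", "known", "first", "only" and "open" are said of these compounds alone.

Two compounds share a piperidine amide core carrying a cyclopropyl sulfonamide. Compound 1 `CS(=O)(=O)c1ccc(C(=O)N2CCC(N(C3CC3)S(=O)(=O)c3cccc(C(F)(F)F)c3)CC2)cc1` gives 52% in an assay on HEK293 cells for inhibition of Voltage-dependent N-type calcium channel subunit alpha-1B (Homo sapiens), read by FLIPR and calcium flux, tested at 1 uM; a lower number here means less inhibition, a higher number more inhibition at the concentration tested (going by the name of the read-out). For the measured compounds named here, compound 2 `CS(=O)(=O)c1cccc(C(=O)N2CCC(N(C3CC3)S(=O)(=O)c3cccc(C(F)(F)F)c3)CC2)c1` gives 15% in this assay and stands lowest of the two numbers; the only measured step, a number 37 percentage points lower from compound 1 to compound 2 (beyond the scatter), is large and beyond the scatter. Compound 3 `NC(=O)c1ccc(C(=O)N2CCC(N(C3CC3)S(=O)(=O)c3cccc(C(F)(F)F)c3)CC2)cc1` has not yet been measured. It differs from compound 2 as follows: 4-carbamoylphenyl in place of 3-(methylsulfonyl)phenyl on a carbonyl carbon. The step from compound 1 to compound 2 bears on this, since it shows how much the four-substituted ring of compound 1 outscored the three-substituted ring of compound 2, although the group in compound 3 is a different one. Compound 3 is therefore expected to move back upward, by roughly a number 20 percentage points higher from compound 2 to compound 3 (beyond the scatter), but with wide uncertainty. Compound 3 is estimated at 35%, between 10% and 60%.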

Compound 3, a percentage reported as inhibition, at one concentration (the size of the read-out at that concentration, not a potency): 12%
For compound 3 the middle estimate is 23 percentage points above the measured one; low and high end bracket the measured number.
By their numbers in this assay, from the lowest: compounds 3 and 2 (each within the scatter of the next); then compound 1.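

In this assay, exchanging methylsulfonyl for carbamoyl on an aromatic carbon, with the place on the ring unchanged, gives a number 40 percentage points lower from compound 1 to compound 3 (beyond the scatter), so the higher number of compound 1 does not follow from the place on the ring alone but also depends on the group held there. The other step is a number 3 percentage points lower from compound 2 to compound 3 (within the scatter), so 4-carbamoylphenyl and 3-(methylsulfonyl)phenyl cannot be told apart here, and among these three compounds only 4-(methylsulfonyl)phenyl stands apart. Nothing available accounts for this difference between the two groups.

From the compounds shown here alone, it remains open how 3-carbamoylphenyl would compare with 4-carbamoylphenyl. Going by these compounds, it is also open whether an ethylsulfonyl group, a nitrile or a carboxylic acid in that place would come closer to methylsulfonyl or to carbamoyl.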